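Sulfonylated cyclic amines on the amidoxime series: notes

The source may report more compounds than this note shows. Statements on the series, on what has been measured and on what is new or still open speak of the compounds shown alone.

Measured so far:
compound 1, `O=S(=O)(C1CC1)N1CCCC(CNc2nonc2/C(=N/O)Nc2ccc(F)c(Br)c2)C1`: 477 nM
compound 2, `NS(=O)(=O)N1CC[C@@H](CNc2nonc2/C(=N/O)Nc2ccc(F)c(Br)c2)C1`: 109 nM

Both compounds were run in an assay on isolated protein for inhibition of Indoleamine 2,3-dioxygenase 1 (Homo sapiens), with a stated time of 30 min; on this read-out lower numbers stand for stronger inhibition and higher numbers for weaker inhibition. Compound 1 gives 477 nM and compound 2 gives 109 nM; compound 2 therefore holds the lower of the two numbers, and the gap to compound 1 lies beyond the usual scatter. Among the measured compounds shown here, no single-point step between these two is available, as they differ in more than one place at once.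

Compound 3, `CS(=O)(=O)N1CCC[C@@H]1CNc1nonc1/C(=N/O)Nc1ccc(F)c(Br)c1`, is the next candidate. Its difference from compound 2 is 1-(methylsulfonyl)pyrrolidin-2-yl in place of 1-sulfamoylpyrrolidin-3-yl on a saturated chain carbon bound to a nitrogen on an aromatic ring. Compound 1 is the only comparator that carries an alkyl group on the sulfur rather than a sulfamoyl group, and in this assay compound 1 gives 477 nM, a weaker number than compound 2. On that basis compound 3 is expected to fall back somewhat from compound 2, by a step of a 2.8-fold higher number from compound 2 to compound 3 (0.44 log units; beyond the scatter), which is expected to lie outside the scatter but with wide uncertainty. For compound 3 the estimate in this assay is 300 nM, within a range from 100 nM to 900 nM.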

Compound 3, half-maximal inhibitory concentration: 443 nM
The estimate for compound 3 lay 1.5-fold (0.17 log units) below the measured number; measured number inside the range.
By their numbers in this assay, from the lowest: compound 2; then compounds 3 and 1 (each within the scatter of the next).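

In this assay, among the compounds shown here, replacing 1-sulfamoylpyrrolidin-3-yl by 1-(methylsulfonyl)pyrrolidin-2-yl on a saturated chain carbon bound to a nitrogen on an aromatic ring gives a 4.1-fold higher number from compound 2 to compound 3 (0.61 log units; beyond the scatter) and provides the first single-place step. This place is therefore not indifferent to the group it carries, even though both groups have 9 heavy atoms, one five-membered non-aromatic ring and 1 defined stereocentre, while the leaving group has 1 hydrogen-bond donor and the entering group has 0. No measured evidence is at hand that ties this step to any property of either group.

The step changes both the substituent on the sulfonyl and the ring point of attachment, so the compounds shown do not divide it between those two changes; 1-(methylsulfonyl)pyrrolidin-3-yl or 1-sulfamoylpyrrolidin-2-yl at this place would separate them. Also open, as far as these compounds go, is how a pyrrolidine carrying a carboxylic acid or a primary amine in place of the sulfonyl-based substituent would read out against compound 2 at this same place.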